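Amide replacement in a shared-core series: notes toward compound 3

The source may report more compounds than this note shows. Statements on the series, on what has been measured and on what is new or still open speak of the compounds shown alone.

Compound 1 `Cn1c(/C=C2\SC(=O)N(CC(=O)Nc3cc(C(C)(C)C)on3)C2=O)nc2ccccc21` carries the shared core of the series. In a functional assay on PC-3 cells (Homo sapiens) for inhibition, read by MTT assay, with a stated time of 48 h (on this read-out lower numbers stand for stronger inhibition and higher numbers for weaker inhibition), compound 1 reaches only the limit > 50000 nM. Compound 2 `CCn1c(/C=C2\SC(=O)N(CC(=O)Nc3cc(C(C)(C)C)on3)C2=O)nc2ccccc21` is the next member; the step that the two limits leave unreadable from compound 1 to compound 2 is methyl in place of hydrogen on a saturated chain carbon bound to an aromatic nitrogen. In this assay compound 2 likewise gives only the limit > 50000 nM. For the measured compounds named here, compound 2 therefore stands at the limit, as does every value shown (the limit of > 50000 nM in this assay, at which 2 of the 2 values shown sit), and no measured step in the set has a readable size. Compound 3 `CCn1c(/C=C2\SC(=O)N(CC(=O)N3CC(C)OC(C)C3)C2=O)nc2ccccc21` takes the change (2,6-dimethylmorpholin-4-yl in place of (5-(tert-butyl)-1,2-oxazol-3-yl)amino on a carbonyl carbon), 2,6-dimethylmorpholin-4-yl in place of (5-(tert-butyl)-1,2-oxazol-3-yl)amino on a carbonyl carbon. Going by the values given here, no measured step bears on this change; the single step from compound 1 to compound 2 sits at the limit and offers no size. The expected step in this assay is a step that the limit leaves unreadable from compound 2 to compound 3, with no direction readable. Compound 3 is estimated at 60000 nM, within 15000 nM to 200000 nM, most likely again reported only as a limit.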

Compound 3, half-maximal inhibitory concentration: > 50000 nM
Compound 3 gave a limit, no number; the forecaster's own chance of this, stated with the estimate: 80%; the middle value lies beyond the limit too.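

Compound 2 and compound 3 both give only a limit, not a number, so no step between them can be read: the limit of > 50000 nM in this assay, at which 3 of the 3 values shown sit.

The compounds shown leave open whether any change on the shared core gives a measurable value in this assay, and how large its effect would be.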